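This account rests on a few compounds, and the source may have more. Where it says the series, first, only, none or still open, it means among the compounds named here.

The measured compounds are compound 1 `Cc1ccc([C@@H](C)Oc2cc3onc(CCC(=O)O)c3cc2Cl)nc1`, compound 2 `C[C@@H](Oc1cc2oc(=O)n(CCC(=O)O)c2cc1Cl)c1ccc(F)cn1` and compound 3 `C[C@@H](Oc1cc2oc(=O)n(CCC(=O)O)c2cc1Cl)c1cccnn1`. In an assay on HEK293 cells for inhibition of kynurenine 3-monooxygenase (Homo sapiens), read by LC-MS, with a stated time of 20 h (a higher number here means a weaker inhibitor, a lower number a stronger inhibitor), compound 1 gives 1.59 nM, compound 2 gives 25.1 nM and compound 3 gives 631 nM. Compound 1 thus stands lowest of the three, well clear of the others. Within the data shown here, the only one-place step among them, a 25-fold higher number from compound 2 to compound 3 (1.40 log units; beyond the scatter), swaps the whole ring on the saturated chain carbon and does not bear on the change at hand. Compound 4 `C[C@@H](Oc1cc2onc(CCC(=O)O)c2cc1Cl)c1ccc(F)cn1` differs from compound 1 by fluoro in place of methyl on an aromatic carbon. Compounds 1 and 2 differ in two places at once, so their gap cannot be assigned to this change. With nothing bearing on it directly, a step of a 1.6-fold higher number from compound 1 to compound 4 (0.20 log units; within the scatter) in this assay is expected, within or just beyond the scatter. Compound 4 is estimated at 2.5 nM, ranging from 1 nM to 8 nM.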

Compound 4, half-maximal inhibitory concentration: 31.6 nM
For compound 4 the middle estimate is 13-fold (1.10 log units) below the measured one, and the stated range ends below it.
By their numbers in this assay, from the lowest: compound 1; then compounds 2 and 4 (each within the scatter of the next); then compound 3.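

Fluoro in place of methyl on this aromatic carbon, two atoms from the ring nitrogen, gives a 20-fold higher number from compound 1 to compound 4 (1.30 log units; beyond the scatter) in this assay and shows that this position is highly sensitive on the core of compound 1, although one heavy atom simply replaces another. The earlier compounds shown here showed only a whole-ring swap, not a change this small. Nothing measured here explains the step. From the compounds shown here alone, whether chloro or methoxy at this position would read nearer compound 1 or compound 4 remains open. So does whether methyl would give a similar step on the core of compound 2.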